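The source may hold more compounds than are shown below. What is called first, only, known or untested is meant among the compounds shown, and "the series" means these compounds.

Three measured members share one core: compound 1 `COc1ccc(-c2cc(/C=C/C(=O)c3ccc(OC)c(OC)c3)[nH]n2)cc1`, compound 2 `COc1ccc(C(=O)/C=C/c2cc(-c3cc(OC)c(OC)c(OC)c3)n[nH]2)cc1` and compound 3 `COc1cc(C(=O)/C=C/c2cc(-c3cc(OC)c(OC)c(OC)c3)n[nH]2)cc(OC)c1OC`. In a functional assay on UO-31 cells (Homo sapiens) for cytotoxicity, read by sulforhodamine B assay, with a stated time of 48 h, tested at 0.1 uM (on this read-out lower numbers stand for a stronger effect and higher numbers for a weaker effect at the one concentration tested), compound 1 gives 87%, compound 2 gives 96% and compound 3 gives 90%. Compound 2 holds the highest of the three numbers, yet compound 3 and compound 1 both lie within the scatter of it, so the three read as alike. Among the measured compounds shown here, no pair of measured compounds differs in only one place. Compound 4 `COc1cc(-c2cc(/C=C/C(=O)c3ccc(F)c(F)c3)[nH]n2)cc(OC)c1OC` has not been measured in this assay. Relative to compound 2 the change is 3,4-difluorophenyl in place of 4-methoxyphenyl on a carbonyl carbon. For the measured compounds named here, no measured pair shows what such a change does here, so the expected step of a number 6 percentage points lower from compound 2 to compound 4 (within the scatter) is none beyond the scatter. Compound 4 is estimated at 90%, with a range from 75% to 102%.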

Compound 4, a percentage reported as activity, at one concentration (the size of the read-out at that concentration, not a potency): 86%
Beside the measured number, compound 4's estimate is 4 percentage points above it; low and high end bracket the measured number.
By their numbers in this assay, from the lowest: compounds 4, 1, 3 and 2 (each within the scatter of the next).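

In this assay, among the compounds shown here, 3,4-difluorophenyl in place of 4-methoxyphenyl on a carbonyl carbon gives a number 10 percentage points lower from compound 2 to compound 4 (within the scatter), the first step that can be read at one place. At this position, the two aryl groups therefore read as alike at the one concentration tested. No measured property is available that bears on this result.

From the compounds shown here alone, whether an amine or a carboxylic acid on this phenyl ring would move the number beyond the scatter remains open. The same holds for a longer chain in its place.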